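The source may hold more compounds than are shown below. What is called first, only, known or untested is meant among the compounds shown, and "the series" means these compounds.

Compound 1 `COC(=O)C1=C(N)Oc2c(OC)cc(Br)cc2C1CC(=O)c1cccc(OC)c1` and compound 2 `COC(=O)C1=C(N)Oc2c(OC)cc(Br)cc2C1CC(=O)c1ccc(Br)cc1` share one core, while compound 3 `COc1cccc(C(=O)CC2C(C#N)=C(N)Oc3ccc(Br)cc32)c1` and compound 4 `N#CC1=C(N)Oc2ccc(Br)cc2C1CC(=O)c1ccc(Br)cc1` share another; the difference between the two cores is not broken down here. In a functional assay on MCF7 cells (Homo sapiens) for antiproliferative activity, read by sulforhodamine B assay, with a stated time of 72 h, tested at 10 uM (on this read-out higher numbers stand for a weaker effect at the one concentration tested and lower numbers for a stronger effect), compound 1 gives 142%, and compound 2 gives 50.2%. The change that separates them, (4-bromophenyl in place of 3-methoxyphenyl on a carbonyl carbon), makes a step of a number 91.8 percentage points lower from compound 1 to compound 2 (beyond the scatter). Compound 3 gives 51.2% in this assay, a number close to that of compound 2 and far from that of compound 1.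

Compound 4 carries the same change against compound 3, (4-bromophenyl in place of 3-methoxyphenyl on a carbonyl carbon), at a place described in the same words as before; among the four compounds this change occurs twice, once between measured compounds and once leading to an unmeasured one. Compound 4 has not yet been tested in this assay.

The step from compound 3 to compound 4 is expected to be a good deal smaller than the earlier one, a number 13.2 percentage points lower from compound 3 to compound 4 (beyond the scatter), because compound 3 already starts from 51.2%, leaving little room for a fall of the earlier size. On that footing compound 4 is estimated to give 38% in this assay, with an expected range from 12% to 68%.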

Compound 4, a percentage reported as activity, at one concentration (the size of the read-out at that concentration, not a potency): 47.2%
The estimate for compound 4 lay 9.2 percentage points below the measured number; measured number inside the range.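

In this assay, the replacement of 3-methoxyphenyl by 4-bromophenyl on a carbonyl carbon gives a step of a number 4 percentage points lower from compound 3 to compound 4 (within the scatter), so the large fall seen on the core of compound 1 does not reappear on the core of compound 3. The change therefore cannot be carried from one core to the other in this series with its size intact: the same change on two cores in this assay, a number 91.8 percentage points lower (beyond the scatter) from compound 1 to compound 2 and a number 4 percentage points lower (within the scatter) from compound 3 to compound 4, 87.8 percentage points apart, beyond the scatter of two such steps This does not show which part of the difference between the two cores goes with the gap, since that difference is not broken down here, and one pair on each core gives no rule for any further core or for any other change at this place.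

The compounds shown leave open whether the methyl ester, the nitrile or the methoxy group on the fused ring system's benzene part goes with the difference between the two steps, as no pair here changes one of these alone. They also leave open how this read-out would respond to a carboxylic acid or a primary amide in place of the ester or nitrile, or to a longer chain between the core and the carbonyl.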